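Longer alkoxy chain on the shared core: compound 2 to compound 3

The compounds below may be only part of what the source reports. "The series", "measured", "known", "first", "only" and "open" are said of these compounds alone.

Compound 1 `COc1cc(CN(C)C(=O)c2c(OCCCC3CCN(C(=O)OC(C)(C)C)CC3)c3ccccc3n(C)c2=O)cc(OC)c1` — 19 nM
Compound 2 `CCCOc1c(C(=O)N(C)Cc2cc(C(F)(F)F)cc(C(F)(F)F)c2)c(=O)n(C)c2ccccc12` — "not determined" (no result reported)

In an assay for inhibition of phosphatidylcholine:ceramide cholinephosphotransferase 2 (Mus musculus), read by mass spectrometry, with stated times of 60 min and 30 min (on this read-out higher numbers stand for weaker inhibition and lower numbers for stronger inhibition), compound 1 gives 19 nM. In this assay, among the compounds with values here, compound 2 stands without a number, its entry reading "not determined" (no result reported), so no measured step connects it to compound 3 `CC(C)CCOc1c(C(=O)N(C)Cc2cc(C(F)(F)F)cc(C(F)(F)F)c2)c(=O)n(C)c2ccccc12`. The change from compound 2 to compound 3 is isopropyl in place of methyl on a saturated chain carbon, two bonds along the chain from an oxygen on an aromatic ring. With no measured reference for compound 2, the step cannot be sized from the data; the expectation is for a change of modest size at most in this assay, with no clear direction. Compound 3 is estimated at 30 nM in this assay, within a range from 5 nM to 200 nM.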

Compound 3, half-maximal inhibitory concentration: 260 nM
For compound 3 the middle estimate is 8.7-fold (0.94 log units) below the measured one, and the stated range ends below it.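

Within the data shown here, compound 2 carries no number, and no step to compound 3 can be read from these results. From the compounds shown here alone, what the change from propoxy to isopentyloxy does to inhibition stays open. No measured evidence bears on this result.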